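Swapping the pyridine on the piperazine of compound 1

The source may hold more compounds than are shown below. What is called first, only, known or untested is meant among the compounds shown, and "the series" means these compounds.

Measured compounds:
- compound 1, `Cc1ccncc1N1CCN(C(=O)CCS(=O)(=O)c2cccc3ncsc23)CC1`: in an ADME assay on microsomes from liver (Rattus norvegicus) for metabolic stability, read by LC-MS, with a stated time of 15 min, tested at 1 uM (on this read-out higher numbers stand for a more stable compound and lower numbers for a less stable compound), compound 1 gives "not determined" (no result reported)
- compound 2, `Cc1cc(F)cnc1N1CCN(C(=O)CCCc2cccc3ncsc23)[C@@H](C)C1`: in this assay compound 2 gives 5.3%

Compound 1 carries the sulfone-linked core and a methylpyridinyl on the piperazine nitrogen. For compound 1 the entry in this assay reads "not determined" (no result reported), so it cannot be placed on the scale at all. Within the data shown here, the only measured point is compound 2, whose value in this assay shows a compound that is largely consumed over the incubation. Compound 2 differs from compound 1 and from compound 3 in several places, so its value does not define a step to either.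

Compound 3, `O=C(CCS(=O)(=O)c1cccc2ncsc12)N1CCN(c2ccc(Cl)cn2)CC1`, keeps the whole core of compound 1 and changes one group: 5-chloropyridin-2-yl in place of 4-methylpyridin-3-yl on an amine nitrogen in a ring. Among the measured compounds shown here, no measured pair shows this change, so no size of step can be read for it; the expectation is that compound 3 lands anywhere from the low end seen for compound 2 to a clearly more stable read-out, with no direction beyond the scatter that the data can support. On that basis compound 3 is estimated to give 30% in this assay, with a range from 6% to 65%.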

Compound 3, percent of the compound remaining: 31%
Compound 3: middle estimate off by 1 percentage points, on the low side, and the stated range covers the measured number.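

No step can be read from the result for compound 3: in this assay compound 1 gives "not determined" (no result reported) and compound 2 differs from compound 3 in several places. The compounds shown leave open what replacing 4-methylpyridin-3-yl with 5-chloropyridin-2-yl does to this read-out. Nothing available bears on the result.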